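The source may report more compounds than this note shows. Statements on the series, on what has been measured and on what is new or still open speak of the compounds shown alone.

Measured in an ADME assay on Vero cells (Chlorocebus sabaeus) for cytotoxicity, read by MTT assay, with a stated time of 72 h; on this read-out higher numbers stand for weaker inhibition and lower numbers for stronger inhibition:
Compound 1 `O=C(O)c1cn(C2CC2)c2nc(N3CCN(C(c4ccccc4)c4ccc(Cl)cc4)CC3)c([N+](=O)[O-])cc2c1=O`: 112000 nM
Compound 2 `CC1CN(c2nc3c(cc2[N+](=O)[O-])c(=O)c(C(=O)O)cn3-c2ccc(F)cc2)CC(C)O1`: 141000 nM
Compound 3 `O=C(O)c1cn(-c2ccc(F)cc2)c2nc(N3CCC(N4CCCCC4)CC3)c([N+](=O)[O-])cc2c1=O`: > 126000 nM (a limit, not a number)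

Compound 1 at 112000 nM and compound 2 at 141000 nM lie within the usual scatter of each other. Compound 4 `CC(C)(C)n1cc(C(=O)O)c(=O)c2cc([N+](=O)[O-])c(N3CCN(C(c4ccccc4)c4ccc(Cl)cc4)CC3)nc21` keeps the rest of compound 1 but carries tert-butyl in place of cyclopropyl on an aromatic nitrogen. Among the compounds with values here, the only measured step, a step that the limit leaves unreadable from compound 2 to compound 3, cannot be read and concerns an aromatic carbon, so it gives no size to carry over. In this assay, no change beyond the scatter is expected, and the estimated step is a 1.1-fold lower number from compound 1 to compound 4 (0.05 log units; within the scatter). Compound 4 is expected at about 100000 nM, with an estimated range of 45000 nM to 220000 nM.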

Compound 4, half-maximal inhibitory concentration: > 108000 nM
Compound 4 was reported as a limit (the forecaster's own chance of this, stated with the estimate: 30%); at least 1.0-fold (0.03 log units) between middle value and limit.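

The step from compound 1 to compound 4 cannot be read: compound 4 is reported only as a limit, not a number. The compounds shown leave open how far tert-butyl in place of cyclopropyl on an aromatic nitrogen shifts the reading in this assay.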